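The source may report more compounds than this note shows. Statements on the series, on what has been measured and on what is new or still open speak of the compounds shown alone.

Compound 1 `Cn1nc2c(=O)n(CC3(O)CCN(Cc4ccc(-c5ccco5)cc4Cl)CC3)cnc2c1-c1ccc(C2(N)CC2)cc1`: 0.617 h
Compound 2 `Cn1nc2c(=O)n(CC3(O)CCN(Cc4ccc(-c5ccco5)cc4Cl)CC3)cnc2c1-c1ccc(CNC=O)cc1`: 0.55 h
Compound 3 `CNCc1ccc(-c2c3ncn(CC4(O)CCN(Cc5ccc(-c6ccco6)cc5Cl)CC4)c(=O)c3nn2C)cc1`: 0.533 h

All three compounds were tested in an ADME assay on microsomes from liver (Rattus norvegicus) for metabolic stability; on this read-out lower numbers stand for a shorter-lived compound and higher numbers for a longer-lived compound. Compound 3, at 0.533 h, cannot be told apart from the other two, as each gap lies within the usual scatter of repeat measurements.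

The next compound, compound 4 `Cn1nc2c(=O)n(CC3(O)CCN(Cc4ccc(-c5ccco5)cc4Cl)CC3)cnc2c1-c1ccc(CNS(C)(=O)=O)cc1`, differs from compound 3 at one place: methylsulfonyl in place of methyl on an amine nitrogen. In words, methylsulfonyl stands in place of methyl on an amine nitrogen, which turns (methylamino)methyl into (methanesulfonamido)methyl.

The closest guide is the step on that same nitrogen, where methyl replaced formyl: a 1.0-fold lower number from compound 2 to compound 3 (0.01 log units; within the scatter). The two steps that replaced the group on the aromatic carbon were also small: a 1.1-fold lower number from compound 1 to compound 2 (0.05 log units; within the scatter) and a 1.2-fold lower number from compound 1 to compound 3 (0.06 log units; within the scatter). So all three changes made so far left this assay within the scatter. Within the data shown here, none of the measured compounds carries methylsulfonyl, however, so this evidence is indirect and a surprise in either direction remains possible.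

On this basis, no step beyond the scatter is expected, and the estimated change is a 1.0-fold higher number from compound 3 to compound 4 (0.01 log units; within the scatter). The half-life of compound 4 is estimated at 0.55 h, with an expected range of 0.32 h to 0.95 h.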

Compound 4, half-life: 0.433 h
For compound 4 the middle estimate is 1.3-fold (0.10 log units) above the measured one; the range from low to high includes it.
By their numbers in this assay, from the lowest: compounds 4, 3, 2 and 1 (each within the scatter of the next).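

The sulfonyl group is new to this nitrogen, and it brings hydrogen-bond acceptors where methyl has none, yet in this assay the exchange gives a 1.2-fold lower number from compound 3 to compound 4 (0.09 log units; within the scatter) and so leaves the half-life indistinguishable from that of the methylamine. The same holds against the formamide, with a 1.3-fold lower number from compound 2 to compound 4 (0.10 log units; within the scatter), and across the widest difference in the group on the aromatic carbon, with a 1.4-fold lower number from compound 1 to compound 4 (0.15 log units; within the scatter), so the four groups compared so far, including one that carries a sulfonyl, all fall within the scatter of one another in this assay. No measurement shown gives a reason for the size of these steps.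

As far as these compounds go, it remains open whether a longer chain on the sulfonyl, such as ethylsulfonyl, or a quite different group in this place, such as a carboxylic acid or a dimethylamino group, would also leave the half-life within the scatter. The rest of the molecule is the same in all four compounds, so what sets the short half-life they share cannot be read from them, and changes elsewhere, for example to the chlorine, could matter more than this one.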